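Urea in Place of Amide: Expected Gain on Cells

The compounds below may be only part of what the source reports. "The series", "measured", "known", "first", "only" and "open" are said of these compounds alone.

Measured compounds:
compound 1 `COc1cc(-c2nn(-c3cccc(NC(=O)c4cccc(C(F)(F)F)c4)c3)cc2-c2ccncc2)ccc1Cl`: > 50000 nM (a limit)
compound 2 `COc1cc(-c2nn(-c3cccc(NC(=O)Nc4cccc(C(F)(F)F)c4)c3)cc2-c2ccncc2)ccc1Cl`: 4650 nM
compound 3 `COc1cc(-c2nn(-c3cccc(NC(=O)c4ccc(Cl)c(C(F)(F)F)c4)c3)cc2-c2ccncc2)ccc1Cl`: > 32500 nM (a limit)

Three compounds share one core and differ on the carbonyl carbon of the side chain. In a functional assay on M14 cells (Homo sapiens) for inhibition, read by sulforhodamine B assay, with a stated time of 48 h (on this read-out lower numbers stand for higher toxicity in this test and higher numbers for lower toxicity in this test), compound 1 gives only a limit, > 50000 nM. Compound 2 gives 4650 nM, so an at least 10-fold lower number from compound 1 to compound 2 (1.03 log units; beyond the scatter). Compound 3 gives only a limit, > 32500 nM. Between them, an at least 6.9-fold higher number from compound 2 to compound 3 (0.84 log units; beyond the scatter), while a step that the two limits leave unreadable from compound 1 to compound 3, because the limit of > 32500 nM in this assay, at which 1 of the 3 values shown sits, and the limit of > 50000 nM in this assay, at which 1 of the 3 values shown sits, leave no readable gap. Compound 3 therefore stands at a limit, with no number of its own.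

Compound 4 `COc1cc(-c2nn(-c3cccc(NC(=O)Nc4ccc(Cl)c(C(F)(F)F)c4)c3)cc2-c2ccncc2)ccc1Cl` is the next step: (4-chloro-3-(trifluoromethyl)phenyl)amino in place of 4-chloro-3-(trifluoromethyl)phenyl on a carbonyl carbon. The measured step that bears on it is the amide-to-urea change from compound 1 to compound 2, where an at least 10-fold lower number from compound 1 to compound 2 (1.03 log units; beyond the scatter). The same change applied to compound 3 is expected to give an at least 13-fold lower number from compound 3 to compound 4 (1.11 log units; beyond the scatter) in this assay, a lower number. Compound 4 is estimated at 2500 nM, within 800 nM to 8000 nM.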

Compound 4, concentration lethal to 50% of the cells: 19100 nM
Compound 4: the middle estimate sits 7.6-fold (0.88 log units) below what was measured; the measured number lies above the stated range.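

On the urea side chain, chloro in place of hydrogen on an aromatic carbon now has a readable size, a 4.1-fold higher number from compound 2 to compound 4 (0.61 log units; beyond the scatter), which the amide pair could not give. Against the amide carrying the same 4-chloro-3-(trifluoromethyl)phenyl group, the urea gives an at least 1.7-fold lower number from compound 3 to compound 4 (0.23 log units; that floor lies within the scatter), so on its own this floor does not confirm that the large effect of the urea seen without the chloro carries over. Taken from the amide without chloro, the combined change gives an at least 2.6-fold lower number from compound 1 to compound 4 (0.41 log units; beyond the scatter), and in this assay compound 4 therefore keeps only part of the drop that the urea alone brought in compound 2.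

The true size of the urea step on the chlorinated side chain stays open, because compound 3 has only a limit and no number of its own: the limit of > 32500 nM in this assay, at which 1 of the 4 values shown sits. The compounds shown also do not tell whether the higher number is particular to chloro or would follow another group on that aromatic carbon, such as a fluoro, a methyl or an amine.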